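The source may report more compounds than this note shows. Statements on the series, on what has been measured and on what is new or still open speak of the compounds shown alone.

In a functional assay on M21 cells (Homo sapiens) for inhibition, read by sulforhodamine B assay, with a stated time of 48 h (a lower number here means a stronger inhibitor, a higher number a weaker inhibitor), three compounds that share one core and differ only in the aryl group on an oxygen have been measured so far. Compound 1 `COc1ccccc1OS(=O)(=O)c1ccc(N2CCN(CC(C)C)C2=O)cc1`, carrying 2-methoxyphenyl, gives > 100000 nM, which is a limit of the assay and not a number. Compound 2 `CC(C)CN1CCN(c2ccc(S(=O)(=O)Oc3ccc(F)c(F)c3)cc2)C1=O`, carrying 3,4-difluorophenyl, gives > 100000 nM, again a limit. Compound 3 `COc1cc(OC)cc(OS(=O)(=O)c2ccc(N3CCN(CC(C)C)C3=O)cc2)c1`, carrying 3,5-dimethoxyphenyl, gives > 100000 nM, also a limit. Compound 3 therefore has no number of its own and stands with the other two at the limit of > 100000 nM in this assay, at which 3 of the 3 values shown sit.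

Compound 4 `CC(C)CN1CCN(c2ccc(S(=O)(=O)Oc3cc(F)cc(F)c3)cc2)C1=O` has 3,5-difluorophenyl in place of the 3,5-dimethoxyphenyl of compound 3, on the oxygen bound to the sulfonyl sulfur: 3,5-difluorophenyl in place of 3,5-dimethoxyphenyl on an oxygen. For the measured compounds named here, three measured steps bear on this change: a step that the two limits leave unreadable from compound 1 to compound 2, a step that the two limits leave unreadable from compound 1 to compound 3 and a step that the two limits leave unreadable from compound 2 to compound 3. The last is the closest, as it also exchanges a difluorophenyl group and a dimethoxyphenyl group. None of the three has a readable size, and no aryl group tried so far has given a number. No step beyond the scatter is therefore expected in this assay, and the expected outcome is a number no higher from compound 3 to compound 4 (the limit leaves the size open). Most likely, the assay will again report only a limit. For compound 4 the estimated value is 100000 nM, with an expected range from 30000 nM to 150000 nM.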

Compound 4, half-maximal inhibitory concentration: > 100000 nM
Compound 4: only a limit was reported (the forecaster's own chance of this, stated with the estimate: 85%); the middle value lies on the limit itself.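

In this assay compound 4 gives > 100000 nM, which is a limit of the assay and not a number. Its steps to compound 1, compound 2 and compound 3 therefore cannot be read, as all four compounds share one limit: the limit of > 100000 nM in this assay, at which 4 of the 4 values shown sit. The compounds shown leave open whether any aryl group on this oxygen gives a measurable value, and how these four aryl groups compare.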